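Cytotoxicity notes on an isoquinolinedione hydroxamate amide series

The source may report more compounds than this note shows. Statements on the series, on what has been measured and on what is new or still open speak of the compounds shown alone.

Measured so far in an ADME assay on MT4 cells (Homo sapiens) for cytotoxicity, read by MTT assay; a higher number here means that more compound is tolerated, a lower number that less compound is tolerated:
compound 1, `O=C(C1C(=O)N(O)C(=O)c2ccccc21)N1CCCCC1`, 120000 nM
compound 2, `CCCCCNC(=O)C1C(=O)N(O)C(=O)c2ccccc21`, 130000 nM

Compound 2 holds the highest of the two numbers in this assay, but its nearest neighbour, compound 1, sits within the scatter of it, so no order between the two can be read. Within the data shown here, the only measured step, a 1.1-fold higher number from compound 1 to compound 2 (0.03 log units; within the scatter), exchanged the whole amide substituent without any movement beyond the scatter.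

Compound 3, `CCCCCCCCNC(=O)C1C(=O)N(O)C(=O)c2ccccc21`, is not yet measured. Its change from compound 2 is propyl in place of hydrogen on a saturated chain carbon, five bonds along the chain from an amide-type nitrogen. Among the measured compounds shown here, no measured step extends the chain in this way, so nothing here bears directly on it; the one step available shows the amide substituent could be varied with no effect on the read-out. On that basis the step from compound 2 to compound 3 in this assay is expected to be small, if anything a slight drop, within or near the scatter.

For compound 3 the expected step is a 1.3-fold lower number from compound 2 to compound 3 (0.11 log units; within the scatter). Compound 3 is therefore estimated at 100000 nM, with a range from 40000 nM to 200000 nM.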

Compound 3, half-maximal cytotoxic concentration: 98500 nM
Beside the measured number, compound 3's estimate is 1.0-fold (0.01 log units) above it; the measured number falls inside the stated range.
By their numbers in this assay, from the lowest: compounds 3, 1 and 2 (each within the scatter of the next).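

In this assay, this position now has a reading of its own: propyl in place of hydrogen on a saturated chain carbon, five bonds along the chain from an amide-type nitrogen, gives a 1.3-fold lower number from compound 2 to compound 3 (0.12 log units; within the scatter) and stays within the scatter. The earlier step exchanged the whole amide substituent, whereas this one only extends a chain already present, so the tolerance seen so far also holds for a change in chain length, at least over this one extension. No supporting evidence accompanies this result, so the step stands as a read-out alone.

Going by these compounds, whether a longer chain such as dodecyl would also stay within the scatter remains open, as does the outcome for a chain ending in an amine or a carboxylic acid, or for a phenyl group on the amide nitrogen. With a single chain extension shown, no trend with chain length can be drawn, and no substituent at this position has yet moved the number beyond the scatter.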